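The compounds below may be only part of what the source reports. "The series", "measured", "known", "first", "only" and "open" are said of these compounds alone.

Compound 1 `O=S(=O)(Nc1ccc(-c2nc3ccccc3o2)cc1)c1ccccc1C(F)(F)F` — in an assay on isolated protein for inhibition of malate dehydrogenase, mitochondrial (Sus scrofa), with stated times of 45 min and 30 min (a lower number here means a stronger inhibitor, a higher number a weaker inhibitor), compound 1 gives > 63000 nM.
Compound 2 `O=S(=O)(Nc1ccc2oc(-c3ccccc3)nc2c1)c1ccccc1C(F)(F)F` — compound 2 gives > 63000 nM.
Compound 3 `C=Cc1ccc(S(=O)(=O)Nc2ccc(-c3nc4ccccc4o3)cc2)cc1` — compound 3 gives > 63000 nM.

Each of these values is a limit of the assay rather than a number. Compound 3 therefore stands at the limit, as the limit of > 63000 nM in this assay, at which 3 of the 3 values shown sit, shows. Compound 1 stands at the same limit. Compound 2 does too. For the measured compounds named here, no step between two measured compounds with a single difference is known, so no measured step offers guidance.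

Compound 4 `O=S(=O)(Nc1ccc(-c2nc3ccccc3o2)cc1)c1ccc(Cl)cc1` is the compound still to be measured. It differs from compound 3 in one place: chloro in place of vinyl on an aromatic carbon.

With every measured compound at the limit, the expected step that the limit leaves unreadable from compound 3 to compound 4 in this assay is none beyond the scatter. Compound 4 is estimated at 100000 nM, within a range from 30000 nM to 300000 nM.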

Compound 4, half-maximal inhibitory concentration: > 63000 nM
Compound 4: only a limit was reported; the forecaster's own chance of this, stated with the estimate: 85%; the middle value is on the limit's open side.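

No new step can be read between compound 3 and compound 4, because both values are limits of the assay rather than numbers: the limit of > 63000 nM in this assay, at which 4 of the 4 values shown sit. The compounds shown leave open how strongly any of them inhibits in this assay.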